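Bromo in place of hydrogen: expectation for compound 3

A few compounds are considered here, and "the series" means these few. Any claim that something is new, unique, unknown or untested is made for them only; others in the source may bear on it.

Measured compounds:
compound 1, `COc1ccc(C(=O)n2c(-c3cn(C)c4ccccc34)nc3ccccc32)cc1OC` — in a functional assay on HepG2 cells (Homo sapiens) for inhibition, read by MTT assay, with a stated time of 24 h (a lower number here means a stronger inhibitor of growth, a higher number a weaker inhibitor of growth), compound 1 gives 8400 nM
compound 2, `COc1cc(C(=O)n2c(-c3cn(C)c4ccccc34)nc3ccccc32)cc(OC)c1OC` — in this assay compound 2 gives 4300 nM

For the measured compounds named here, compound 2 holds the lower of the two numbers, but the only step on record, a 2.0-fold lower number from compound 1 to compound 2 (0.29 log units; within the scatter), lies within the scatter, so no order between compound 1 and compound 2 can be read from it.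

Compound 3, `COc1cc(C(=O)n2c(-c3cn(C)c4ccc(Br)cc34)nc3ccccc32)cc(OC)c1OC`, differs from compound 2 by bromo in place of hydrogen on an aromatic carbon. Going by the values given here, no measured step bears on this change: the one step known, methoxy in place of hydrogen, concerns a different part of the shared core and gives no guide to a bromo entering on the 1-methyl-1H-indol-3-yl group. With nothing to build on, the expectation for compound 3 is no step beyond the scatter, a 1.2-fold lower number from compound 2 to compound 3 (0.09 log units; within the scatter). Compound 3 is therefore estimated at 3500 nM in this assay, with a range of 1000 nM to 12000 nM.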

Compound 3, concentration for 50% growth inhibition: 8200 nM
Compound 3: middle estimate off by 2.3-fold (0.37 log units), on the low side, and the stated range covers the measured number.
By their numbers in this assay, from the lowest: compounds 2, 3 and 1 (each within the scatter of the next).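

Bromo in place of hydrogen, which turns 1-methyl-1H-indol-3-yl into 5-bromo-1-methyl-1H-indol-3-yl, is the first change on this part of the shared core, and in this assay it gives a 1.9-fold higher number from compound 2 to compound 3 (0.28 log units; within the scatter) and so sets no order between the two compounds. This aromatic carbon therefore accepts a bromo without a step beyond the scatter, just as the added methoxy on the other side of the core gave none. No measurement at hand accounts for the number or links it to any property of the bromo.

As far as these compounds go, whether an amine or a carboxylic acid in place of that bromo would move the number beyond the scatter stays open. Also open, from the compounds shown here alone, is whether the same bromo would read alike on compound 1, which carries one methoxy fewer.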